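The compounds below may be only part of what the source reports. "The series", "measured", "known", "first", "only" and "open" are said of these compounds alone.

Of the compounds shown here, three sharing one core have so far been measured in an ADME assay on HEK293 cells for agonist activity at metabotropic glutamate receptor 5 (Rattus norvegicus), read by fluorescence and calcium flux; a higher number here means a larger maximal response, a lower number a smaller maximal response. Compound 1 `CC(C)[C@H](C)NC(=O)c1ccc(C#Cc2cccc(F)c2)cn1` gives 13.1% in this assay. Compound 2 `CCCNC(=O)c1ccc(C#Cc2cccc(F)c2)cn1` gives 8.3%, and compound 3 `CC(C)(CO)NC(=O)c1ccc(C#Cc2cccc(F)c2)cn1` gives 9.3%. The three differ only in the group on the amide-type nitrogen, and none of the steps between them reaches beyond the scatter: a number 4.8 percentage points lower from compound 1 to compound 2 (within the scatter), a number 3.8 percentage points lower from compound 1 to compound 3 (within the scatter) and a number 1 percentage points higher from compound 2 to compound 3 (within the scatter). On the numbers shown, compound 3 sits second highest of the three, with compound 2 nearest and compound 1 furthest, both gaps within the scatter, so that no real order can be read among them.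

Compound 4 `CC(C)(O)CNC(=O)c1ccc(C#Cc2cccc(F)c2)cn1` has not yet been measured. It differs from compound 3 on that same amide-type nitrogen: 2-hydroxy-2-methylpropyl in place of 1-(hydroxymethyl)-1-methylethyl on an amide-type nitrogen. The two have the same atoms, joined differently. Among the measured compounds shown here, every measured step so far alters the group on this nitrogen, and each stays within the scatter, so the step to compound 4 in this assay is expected to stay within the scatter as well, with no direction to be read from it. Compound 4 is therefore expected to give 9.5%, with a range from 3% to 17%. This amounts to an expected a number 0.2 percentage points higher from compound 3 to compound 4 (within the scatter).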

Compound 4, largest response reached (reported as efficacy), in percent of the reference or control that the assay uses: 20%
Compound 4: middle estimate off by 10.5 percentage points, on the low side; the whole stated range lies below it.
By their numbers in this assay, from the lowest: compounds 2, 3, 1 and 4 (each within the scatter of the next, the first and the last beyond it).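

In this assay, the group on the amide-type nitrogen gives its first step beyond the scatter when 2-hydroxy-2-methylpropyl replaces 1-(hydroxymethyl)-1-methylethyl, a number 10.7 percentage points higher from compound 3 to compound 4 (beyond the scatter), so this position responds to how the same atoms are joined and not only to which atoms are present. Placing 1-hydroxy-1-methylethyl in place of ethyl on the saturated chain carbon bound to that nitrogen gives a number 11.7 percentage points higher from compound 2 to compound 4 (beyond the scatter), yet the comparison with the 1,2-dimethylpropyl group gives a number 6.9 percentage points higher from compound 1 to compound 4 (within the scatter), so no order can be read between those two, and compound 3, which also carries a hydroxyl group, stays within the scatter of compound 2, so the presence of a hydroxyl group alone does not go with the higher number. Nothing available accounts for the difference between these two arrangements.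

The compounds shown leave open whether the hydroxyl group matters at all in the 2-hydroxy-2-methylpropyl chain, which the plain 2-methylpropyl chain, the matching methyl ether or the matching amine would test. They also leave open whether a longer chain between the nitrogen and the hydroxyl group would carry the response further or lose it.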